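Methoxycarbonyl Added to the Bromophenyl Ring of Compound 3

The source may hold more compounds than are shown below. What is called first, only, known or untested is meant among the compounds shown, and "the series" means these compounds.

Compound 3 `O=C(O)Cn1c(SCc2ccccc2Br)nc2ccccc21` gives 580 nM in an assay on HEK293 cells for displacement of a labelled ligand from prostaglandin D2 receptor 2 (Homo sapiens); on this read-out lower numbers stand for stronger inhibition and higher numbers for weaker inhibition. Compound 3 stands second highest of the three numbers: compound 1 `O=C(O)Cn1c(SCCc2ccccc2)nc2ccccc21` gives 881 nM, a step of a 1.5-fold lower number from compound 1 to compound 3 (0.18 log units; within the scatter), and compound 2 `O=C(O)Cn1c(SCc2cccc(Br)c2)nc2ccccc21` gives 370 nM, a step of a 1.6-fold higher number from compound 2 to compound 3 (0.20 log units; within the scatter). Compound 4 `COC(=O)c1cccc(CSc2nc3ccccc3n2CC(=O)O)c1Br` differs from compound 3 by methoxycarbonyl in place of hydrogen on an aromatic carbon. Among the measured compounds shown here, no measured step involves a methoxycarbonyl group; the measured steps only move the bromo group, and the largest of them, a 2.4-fold lower number from compound 1 to compound 2 (0.38 log units; beyond the scatter), is modest. For the measured compounds named here, the new group therefore has no precedent here, and the expected step of a 1.2-fold lower number from compound 3 to compound 4 (0.06 log units; within the scatter) is small and of uncertain direction. Compound 4 is estimated at 500 nM, expected to lie between 200 nM and 1400 nM.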

Compound 4, half-maximal inhibitory concentration: 2900 nM
Compound 4: the middle estimate sits 5.8-fold (0.76 log units) below what was measured; measured number above the stated range.
By their numbers in this assay, from the lowest: compounds 2, 3 and 1 (each within the scatter of the next, the first and the last beyond it); then compound 4.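

In this assay, among the compounds shown here, methoxycarbonyl in place of hydrogen on this aromatic carbon, ortho to a bromo group, gives a 5.0-fold higher number from compound 3 to compound 4 (0.70 log units; beyond the scatter) and so marks the first step that clearly weakens inhibition. The earlier steps shown here only moved the bromo group or changed the chain, and they gave no sign that this ring carbon could be so sensitive to a new group. No measurement shown explains the loss. On these data alone, it remains open whether a methyl group, an amide or a free carboxylic acid on the same carbon would cost as much. As far as these compounds go, it also remains open whether methoxycarbonyl would do the same on the ring of compound 2.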